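Fluorophenyl isomers in the antiproliferative series

The compounds below may be only part of what the source reports. "The series", "measured", "known", "first", "only" and "open" are said of these compounds alone.

compound 1 `Cc1ccc(N2CCN(C(=S)SCc3ccc4nc(N)nc(N)c4c3)CC2)cc1` gives 2130 nM
compound 2 `Cc1ccccc1N1CCN(C(=S)SCc2ccc3nc(N)nc(N)c3c2)CC1` reads "not determined" (no result reported)
compound 3 `Nc1nc(N)c2cc(CSC(=S)N3CCN(c4ccc(F)cc4)CC3)ccc2n1` gives 1840 nM

All numbers come from a functional assay on HeLa cells (Homo sapiens) for antiproliferative activity, read by MTT assay, with a stated time of 72 h (a higher number here means a weaker inhibitor, a lower number a stronger inhibitor), and are half-maximal inhibitory concentrations. Among the measured compounds shown here, compound 3, at 1840 nM, holds one of only two numbers. The other belongs to compound 1, and the two lie within the scatter of each other (a 1.2-fold lower number from compound 1 to compound 3 (0.06 log units; within the scatter)), so they cannot be ranked.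

Compound 4 `Nc1nc(N)c2cc(CSC(=S)N3CCN(c4ccccc4F)CC3)ccc2n1` has the same atoms as compound 3, joined differently, with 2-fluorophenyl in place of 4-fluorophenyl on an amine nitrogen in a ring. For the measured compounds named here, the one measured step bears on this only loosely, since it exchanges methyl for fluoro and does not relocate the group. Compound 2 pairs with compound 1 as compound 4 pairs with compound 3 and would be the closest guide, but it has no reported result. Going by the values given here, no measured pair therefore shows what this kind of change does.

Among the compounds with values here, with the small step (a 1.2-fold lower number from compound 1 to compound 3 (0.06 log units; within the scatter)) as the sole guide, no shift beyond the scatter is expected in this assay, and no direction is favoured. The expected step is small (a 1.1-fold higher number from compound 3 to compound 4 (0.04 log units; within the scatter)). Compound 4 is estimated at 2000 nM (expected range 950 nM to 4200 nM).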

Compound 4, half-maximal inhibitory concentration: 6660 nM
Compound 4: middle estimate off by 3.3-fold (0.52 log units), on the low side; measured number outside the range, above it.
By their numbers in this assay, from the lowest: compounds 3 and 1 (each within the scatter of the next); then compound 4.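

In this assay, among the compounds shown here, relocating the fluorine from 4-fluorophenyl to 2-fluorophenyl on the amine nitrogen in the ring gives the first step beyond the scatter, with a 3.6-fold higher number from compound 3 to compound 4 (0.56 log units; beyond the scatter) and compound 4 as the weakest of the three compounds with numbers. The exchange of 4-methylphenyl for 2-fluorophenyl gives a modest step of its own, a 3.1-fold higher number from compound 1 to compound 4 (0.50 log units; beyond the scatter), while the exchange of methyl for fluoro with the group left in place stays within the scatter at a 1.2-fold lower number from compound 1 to compound 3 (0.06 log units; within the scatter), so among these three compounds the location of the group on the phenyl ring is what separates the numbers, not the identity of the group. Why the 2-fluorophenyl compound gives the higher number cannot be said, as no measurement here bears on the cause of this shift.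

On these data alone, whether this penalty belongs to fluorine alone or also applies to other groups on the phenyl ring, such as chloro or methoxy, remains open. Also open, as far as these compounds go, is how an unsubstituted phenyl would compare with the three compounds, which would show whether the 4-substituted compounds or compound 4 depart from the parent ring.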